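The compounds below may be only part of what the source reports. "The series", "measured", "known", "first", "only" and "open" are said of these compounds alone.

In a functional assay on HOS-TE85 cells (Homo sapiens) for inhibition, read by CCK-8 assay, with a stated time of 72 h (on this read-out lower numbers stand for stronger inhibition and higher numbers for weaker inhibition), compound 1 (`COc1ccccc1N1C(=O)CSC1c1cc(C(=O)NCCCCc2ccccc2)cc(C2CC2)c1`) gives 23.5 nM and compound 2 (`O=C(NCCCCc1ccccc1)c1cc(F)cc(C2SCC(=O)N2c2ccccn2)c1`) gives 14.2 nM, so the two values lie within the scatter of each other. Compound 3 (`COc1ccccc1N1C(=O)CSC1c1cc(F)cc(C(=O)NCCCCc2ccccc2)c1`) is compound 2 with 2-methoxyphenyl in place of pyridin-2-yl on an amide-type nitrogen in a ring. For the measured compounds named here, no pair of measured compounds shows this exchange on its own. Compound 1 also bears 2-methoxyphenyl on that nitrogen and gives 23.5 nM, which is within the scatter of the value for compound 2. No step beyond the scatter is therefore expected in this assay. The estimated change is a 1.4-fold higher number from compound 2 to compound 3 (0.15 log units; within the scatter), a small expected rise in the number that would stay within the scatter. For compound 3 the estimated value is 20 nM, with an expected range of 8 nM to 50 nM.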

Compound 3, half-maximal inhibitory concentration: 40.9 nM
The estimate for compound 3 lay 2.0-fold (0.31 log units) below the measured number, within the range that was stated.
By their numbers in this assay, from the lowest: compounds 2, 1 and 3 (each within the scatter of the next, the first and the last beyond it).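

In this assay, the exchange on the amide-type nitrogen can now be read on its own: with fluoro kept on the aromatic carbon, 2-methoxyphenyl in place of pyridin-2-yl gives a 2.9-fold higher number from compound 2 to compound 3 (0.46 log units; beyond the scatter), a modest step towards weaker inhibition. The second exchange, fluoro in place of cyclopropyl on an aromatic carbon with 2-methoxyphenyl kept on the nitrogen, gives a 1.7-fold higher number from compound 1 to compound 3 (0.24 log units; within the scatter), so in this pair that change cannot be told from the scatter. Nothing available accounts for the step on the nitrogen.

The compounds shown leave open whether the step follows the ring nitrogen of pyridin-2-yl or the methoxy group of 2-methoxyphenyl, a question that plain phenyl or pyridin-3-yl on the same nitrogen could address. They also leave open whether the step persists with cyclopropyl on the aromatic carbon.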